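Working notes: compound 2 to compound 3

The source may hold more compounds than are shown below. What is called first, only, known or untested is meant among the compounds shown, and "the series" means these compounds.

- compound 1 `CC(C)OCCOC(=O)c1cccc(-c2cc(C(=O)Nc3ccncc3F)ccc2CN)c1`: 0.1 h
- compound 2 `NCc1ccc(C(=O)Nc2ccncc2F)cc1-c1cccc(C(=O)OCC2CCCCO2)c1`: 0.117 h
- compound 3 `NCc1ccc(C(=O)Nc2ccncc2F)cc1-c1cccc(C(=O)O)c1`: not yet measured

These values come from an ADME assay on a cell-free system (plasma, Homo sapiens) for metabolic stability, read by LC-MS; on this read-out higher numbers stand for a longer-lived compound and lower numbers for a shorter-lived compound. Among the compounds with values here, only two numbers exist so far, and compound 2, at 0.117 h, stands level with compound 1 within the scatter.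

The change to compound 3 is hydrogen in place of (oxan-2-yl)methyl on an oxygen next to a carbonyl group, so that ((oxan-2-yl)methoxy)carbonyl becomes carboxy.

Within the data shown here, one measured step bears on this: a 1.2-fold higher number from compound 1 to compound 2 (0.07 log units; within the scatter). It exchanges one group for another further out and leaves that oxygen substituted, so it only weakly guides a change that removes the whole group. Among the measured compounds shown here, no measured compound carries the carboxy group, so the expectation is uncertain. In this assay the expected step is upward and beyond the scatter: a 51-fold higher number from compound 2 to compound 3 (1.71 log units; beyond the scatter). The estimate for compound 3 is 6 h, with an expected range of 1 h to 30 h.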

Compound 3, half-life: > 2 h
Compound 3: only a limit was reported; the forecaster's own chance of this, stated with the estimate: 50%; the middle value lies beyond the limit too.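

In this assay, hydrogen in place of (oxan-2-yl)methyl on an oxygen next to a carbonyl group gives an at least 17-fold higher number from compound 2 to compound 3 (1.23 log units; beyond the scatter), and hydrogen in place of 2-isopropoxyethyl at that same place gives an at least 20-fold higher number from compound 1 to compound 3 (1.30 log units; beyond the scatter). Compound 1 and compound 2 stood level within the scatter, so exchanging one group on this oxygen for another showed little, whereas the carboxy group of compound 3 sets it clearly apart from both. Compound 3 gives > 2 h, which is a limit of the assay and not a number, so both steps give only a lower bound on their size: the limit of > 2 h in this assay, at which 1 of the 3 values shown sits.

The compounds shown leave open how far compound 3 lies beyond that limit. They also leave open whether an amide or a methyl ester on the same carbonyl would stand with compound 3 or with compound 1 and compound 2.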